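This account rests on a few compounds, and the source may have more. Where it says the series, first, only, none or still open, it means among the compounds named here.

compound 1 `COCOc1cccc(C[C@H]2C(=O)OC[C@@H]2Cc2ccccc2)c1` gives 80000 nM
compound 2 `Clc1ccc(C[C@H]2COC[C@@H]2Cc2ccccc2)cc1Cl` gives 19000 nM
compound 3 `Cc1ccc(C[C@H]2COC(=O)[C@@H]2Cc2ccc(Cl)c(Cl)c2)cc1` gives 19000 nM

All three values come from a functional assay on HL-60 cells (Homo sapiens) for cytotoxicity, read by WST assay, with a stated time of 48 h (a lower number here means that less compound is needed, a higher number that more compound is needed for the effect), and no number exists yet for compound 4 `Fc1ccccc1C[C@H]1COC[C@@H]1Cc1ccc(Cl)c(Cl)c1` in this read-out. Compound 2 stands level with compound 3, and the two share the lowest number of the three. Compound 1 reads higher than compound 2, beyond the scatter.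

Compound 4 differs from compound 2 by fluoro in place of hydrogen on an aromatic carbon on one ring, which is phenyl to 2-fluorophenyl, with fluoro in place of hydrogen on an aromatic carbon. For the measured compounds named here, no measured pair differs in one place only, so the data hold no direct guide to this change. The expectation in this assay is therefore no step beyond the scatter, and it rests on compound 2 at 19000 nM as the starting point. The expected change is a 1.1-fold lower number from compound 2 to compound 4 (0.02 log units; within the scatter) in size. Compound 4 is estimated at 18000 nM with an expected range of 8000 nM to 40000 nM once it is measured.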

Compound 4, half-maximal effective concentration: 51000 nM
Beside the measured number, compound 4's estimate is 2.8-fold (0.45 log units) below it, and the stated range ends below it.
By their numbers in this assay, from the lowest: compounds 2 and 3 (each within the scatter of the next); then compounds 4 and 1 (each within the scatter of the next).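

In this assay, for the compounds shown here, the change from phenyl to 2-fluorophenyl gives a 2.7-fold higher number from compound 2 to compound 4 (0.43 log units; beyond the scatter) and is the first step that can be read in one place only. It shows that this aromatic carbon, ortho to a large group, does not tolerate the swap without change: a single fluoro in place of hydrogen moves the read-out beyond the scatter, though only modestly, and toward more compound being needed. No measurement bears on the origin of this step, so its size and direction stand without an explanation.

As far as these compounds go, whether the step is specific to fluoro remains open, since chloro, methyl or methoxy on the same carbon would separate fluoro from other groups. Also open, from the compounds shown here alone, is whether the same change carries over to the core of compound 3.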